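This account rests on a few compounds, and the source may have more. Where it says the series, first, only, none or still open, it means among the compounds named here.

Of the compounds shown here, three that share one core have been tested in a functional assay on the whole organism (strain Sprague-Dawley) for inhibition, with Rattus norvegicus as the target; a higher number here means that more compound is needed for the effect, a lower number that less compound is needed. Compound 1 `CCc1cccc2c(=O)c(-c3nn[nH]n3)c[nH]c12` gives 0.312 mg/kg in this assay. Compound 2 `Cc1ccc2[nH]cc(-c3nn[nH]n3)c(=O)c2c1` gives 1.25 mg/kg. Compound 3 `O=c1c(-c2nn[nH]n2)c[nH]c2c(F)cccc12` gives 0.625 mg/kg. Among the three numbers compound 3 gives the second highest, though its gap to compound 2 and its gap to compound 1 both lie within the usual scatter. For the measured compounds named here, the only step between compounds that differ in a single place, a 2.0-fold higher number from compound 1 to compound 3 (0.30 log units; within the scatter), is also within the scatter.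

Compound 4 `Cc1cc(F)c2[nH]cc(-c3nn[nH]n3)c(=O)c2c1` differs from compound 3 by methyl in place of hydrogen on an aromatic carbon. Going by the values given here, no measured step covers a methyl group entering this place. Compound 2 also carries a methyl group, but it differs from compound 3 in two places, so its value and that of compound 3 show only that the two sit within the scatter of each other. Among the compounds with values here, with the one measured step within the scatter and nothing pointing the other way, the step of a 1.3-fold higher number from compound 3 to compound 4 (0.11 log units; within the scatter) is expected to be small. Compound 4 is therefore estimated at 0.8 mg/kg, within a range from 0.3 mg/kg to 2.5 mg/kg.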

Compound 4, minimum effective dose: 2.5 mg/kg
Beside the measured number, compound 4's estimate is 3.1-fold (0.49 log units) below it; low and high end bracket the measured number.
By their numbers in this assay, from the lowest: compounds 1, 3, 2 and 4 (each within the scatter of the next, the first and the last beyond it).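

In this assay, for the compounds shown here, the methyl group on the aromatic carbon meta to the fluoro group gives a 4.0-fold higher number from compound 3 to compound 4 (0.60 log units; beyond the scatter), the first step here beyond the usual scatter, so more compound is needed once this group enters and this position is not indifferent to the change. The fluoro group tells a different story: with the methyl group already in place, a 2.0-fold higher number from compound 2 to compound 4 (0.30 log units; within the scatter) stays within the scatter, so the effect of adding fluoro cannot be told from noise. No measurement available here explains the effect of the methyl group.

Whether methyl has the same effect without the fluoro group remains open, as no compound shown pairs with compound 2 by lacking only the methyl group. Also open, going by these compounds, is how this position would respond to a chlorine atom, a methoxy group or a longer chain such as propyl.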